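Lengthening the Side Chain: Butyl to Pentyl

The compounds below may be only part of what the source reports. "The series", "measured", "known", "first", "only" and "open" are said of these compounds alone.

Compound 1 `CCCc1cc2ccccc2nc1-c1cc(-c2ccc(C)cc2)no1`: > 100000 nM
Compound 2 `CCCCc1cc2ccccc2nc1-c1cc(-c2ccc(C)cc2)no1`: > 100000 nM

Both measured compounds were tested in a functional assay on COLO 205 cells (Homo sapiens) for inhibition, read by MTT assay, with a stated time of 24 h; on this read-out higher numbers stand for weaker inhibition and lower numbers for stronger inhibition. In this assay compound 1 gives > 100000 nM, which is a limit of the assay and not a number. Compound 2 gives > 100000 nM, likewise a limit. The step that the two limits leave unreadable from compound 1 to compound 2 cannot be read, as both values sit at the limit of > 100000 nM in this assay, at which 2 of the 2 values shown sit. Compound 2 therefore stands only at a limit, with no number of its own.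

Compound 3 `CCCCCc1cc2ccccc2nc1-c1cc(-c2ccc(C)cc2)no1` is not yet measured. It differs from compound 2 by methyl in place of hydrogen on a saturated chain carbon, four bonds along the chain from an aromatic carbon. Among the compounds with values here, the only measured step that bears on this change is the one from compound 1 to compound 2, and that step is unreadable. There is thus no measured basis for expecting a shift in either direction beyond the scatter. Compound 3 is expected to give 200000 nM, within a range of 50000 nM to 1000000 nM, most likely reported again only as a limit. The expected step is a step that the limit leaves unreadable from compound 2 to compound 3.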

Compound 3, half-maximal inhibitory concentration: > 100000 nM
Compound 3: no number, only a limit (the forecaster's own chance of this, stated with the estimate: 85%); the middle value lies beyond the limit too.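

No step can be read among compound 1, compound 2 and compound 3, since each value is a limit of the assay and not a number: the limit of > 100000 nM in this assay, at which 3 of the 3 values shown sit.

The compounds shown leave open whether any chain length on the shared core would give a readable number in this assay.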